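From 5-Chlorothiophen-2-yl to 4-Vinylphenyl on the Sulfonyl

The source may hold more compounds than are shown below. What is called first, only, known or untested is meant among the compounds shown, and "the series" means these compounds.

Three compounds share one core and differ only in the group attached to the sulfonyl sulfur. Compound 1 `O=S(=O)(Nc1ccc(-c2nc3ccccc3o2)cc1)c1cccs1` gives 63000 nM in an assay on cells for inhibition of HSP60/HSP10 (Homo sapiens), with a stated time of 60 min; on this read-out lower numbers stand for stronger inhibition and higher numbers for weaker inhibition. Compound 2 `Cc1ccccc1S(=O)(=O)Nc1ccc(-c2nc3ccccc3o2)cc1` gives 85000 nM, and compound 3 `O=S(=O)(Nc1ccc(-c2nc3ccccc3o2)cc1)c1ccc(Cl)s1` gives 31000 nM. Compound 3 has the lowest number of the three: a 2.0-fold lower number from compound 1 to compound 3 (0.31 log units; beyond the scatter) and a 2.7-fold lower number from compound 2 to compound 3 (0.44 log units; beyond the scatter) both lie beyond the scatter, while a 1.3-fold higher number from compound 1 to compound 2 (0.13 log units; within the scatter) stays within it.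

Compound 4 `C=Cc1ccc(S(=O)(=O)Nc2ccc(-c3nc4ccccc4o3)cc2)cc1` is not yet measured. It differs from compound 3 in one place: 4-vinylphenyl in place of 5-chlorothiophen-2-yl on a sulfonyl sulfur. Going by the values given here, two measured steps bear on this. The step of a 2.0-fold lower number from compound 1 to compound 3 (0.31 log units; beyond the scatter) came with adding the chloro, and the step of a 2.7-fold lower number from compound 2 to compound 3 (0.44 log units; beyond the scatter) came with moving from a six-membered carbon ring to the 5-chlorothiophen-2-yl group. Compound 4 carries neither the chloro nor the five-membered ring, so a step back toward higher numbers is expected, of about a 2.1-fold higher number from compound 3 to compound 4 (0.32 log units; beyond the scatter). The estimate for compound 4 in this assay is 65000 nM, expected to fall between 28000 nM and 150000 nM.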

Compound 4, half-maximal inhibitory concentration: > 100000 nM
Compound 4 was reported as a limit (the forecaster's own chance of this, stated with the estimate: 15%); middle value at least 1.5-fold (0.18 log units) from the limit.
By their numbers in this assay, from the lowest: compound 3; then compounds 1 and 2 (each within the scatter of the next). At a limit, above all of these: compound 4.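

In this assay compound 4 is reported only as a limit, > 100000 nM, so every step to it gives a floor and not a size. The step of an at least 3.2-fold higher number from compound 3 to compound 4 (0.50 log units; beyond the scatter) shows that 4-vinylphenyl on the sulfonyl sulfur does not keep the lower number seen with 5-chlorothiophen-2-yl, and compound 1, which has a five-membered ring but no chloro, already sits within the scatter of compound 2, so ring type alone does not set the number. The other floors, an at least 1.1-fold higher number from compound 2 to compound 4 (0.07 log units; that floor lies within the scatter) and an at least 1.5-fold higher number from compound 1 to compound 4 (0.20 log units; that floor lies within the scatter), lie within the scatter, so how far 4-vinylphenyl stands from those two groups stays unresolved.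

The compounds shown leave open whether a chloro on a six-membered carbon ring would match 5-chlorothiophen-2-yl. They also leave open what an amine or a carboxylic acid on that ring would do.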